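From phenyl to 4-fluorophenyl in compound 3

This account rests on a few compounds, and the source may have more. Where it says the series, first, only, none or still open, it means among the compounds named here.

Going by the values given here, in an ADME assay on microsomes from liver (Mus musculus) for metabolic stability, with a stated time of 10 min, tested at 0.5 uM (on this read-out higher numbers stand for a more stable compound and lower numbers for a less stable compound), compound 1 `CCc1noc(C)c1[C@@H]1C[C@@](C)(c2ccc(F)cc2F)N=C(N)S1` gives 41%, while compound 2 `Cc1onc(-c2ccccc2)c1[C@@H]1C[C@@](C)(c2ccc(F)cc2F)N=C(N)S1` gives 12%, the lower of the two numbers so far. Compound 3 `Cc1onc(-c2ccc(F)cc2)c1[C@@H]1C[C@@](C)(c2ccc(F)cc2F)N=C(N)S1` carries fluoro in place of hydrogen on an aromatic carbon of the phenyl of compound 2, para to a large group: fluoro in place of hydrogen on an aromatic carbon. Among the compounds with values here, only one measured step bears on this change, and only indirectly: phenyl in place of ethyl on an aromatic carbon gave a number 29 percentage points lower from compound 1 to compound 2 (beyond the scatter). Within the data shown here, that step exchanged a whole group, and no measurement yet shows fluoro on this phenyl. A smaller step is therefore expected in this assay, and an upward one is thought more likely since compound 2 stands at 12%. The expected change is a number 4 percentage points higher from compound 2 to compound 3 (within the scatter). For compound 3 the estimate is 16%, with an expected range of 6% to 32%.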

Compound 3, percent of the compound remaining: 23%
Estimate against measurement, compound 3: 7 percentage points below; measured number inside the range.
By their numbers in this assay, from the lowest: compound 2; then compound 3; then compound 1.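

In this assay, going by these compounds alone, this is the first measured change on the phenyl itself, and a single fluoro para to a large group gives a number 11 percentage points higher from compound 2 to compound 3 (beyond the scatter) on its own, a step beyond the usual scatter. The recovery is only partial, as 4-fluorophenyl in place of ethyl still gives a number 18 percentage points lower from compound 1 to compound 3 (beyond the scatter) and leaves the ethyl of compound 1 with the highest number of the three. Nothing measured here accounts for the effect of the fluoro, so the step stands as an observation only.

On these data alone, whether the rise belongs to fluoro in particular stays open, as a chloro, a methoxy or a trifluoromethyl at this place on the phenyl could move the number differently. Also open, as far as these compounds go, is whether a second fluoro on the same phenyl would add to the step.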